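This account rests on a few compounds, and the source may have more. Where it says the series, first, only, none or still open, it means among the compounds named here.

Compound 3 `Cc1c(Cc2cccc(F)c2)c(=O)oc2cc(OCC(O)CN3CCC(C(N)=O)CC3)ccc12` stands with the lowest of the two numbers given in an ADME assay on A549 cells (Homo sapiens) for cytotoxicity, read by CellTiter-Glo; a lower number here means that less compound is tolerated, a higher number that more compound is tolerated: compound 3 gives 53300 nM. Compound 2 `Cc1c(Cc2ccccc2)c(=O)oc2cc(OCC(O)CNCCCO)ccc12` gives 53400 nM, a value within the scatter of compound 3. Compound 1 `Cc1c(Cc2ccccc2)c(=O)oc2cc(OCC(O)CNc3cc([N+](=O)[O-])ccc3O)ccc12` gives only a limit of this assay, > 100000 nM. Among the compounds with values here, the one measured step, an at least 1.8-fold lower number from compound 1 to compound 2 (0.27 log units; that floor lies within the scatter), rests on that limit of > 100000 nM in this assay, at which 1 of the 3 values shown sits, and changes the group on the amine nitrogen, not the part altered now.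

Compound 4 `COC(=O)c1ccc(Cc2c(C)c3ccc(OCC(O)CN4CCC(C(N)=O)CC4)cc3oc2=O)cc1` differs from compound 3 in 4-(methoxycarbonyl)phenyl in place of 3-fluorophenyl on a saturated chain carbon bound to an aromatic carbon. Within the data shown here, no measured step touches this position, so no shift beyond the scatter is expected in this assay; the step of a 1.0-fold lower number from compound 3 to compound 4 (0.00 log units; within the scatter) is the estimate. Compound 4 is therefore expected to give 53000 nM, between 20000 nM and 120000 nM.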

Compound 4, half-maximal cytotoxic concentration: > 100000 nM
Compound 4: a limit, no number (the forecaster's own chance of this, stated with the estimate: 25%); middle value at least 1.8-fold (0.27 log units) away from the limit.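

The change from 3-fluorobenzyl to 4-(methoxycarbonyl)benzyl is the first one shown at this place, and in this assay it gives an at least 1.8-fold higher number from compound 3 to compound 4 (0.27 log units; that floor lies within the scatter). Compound 4 gives a limit rather than a number, so the step has only a floor: the limit of > 100000 nM in this assay, at which 2 of the 4 values shown sit. That floor does not show how far this change moves the number beyond the scatter.

The compounds shown leave open whether the step goes with the loss of the fluorine or with the gain of the methoxycarbonyl group. They also leave open what a carboxylic acid or an amine would give on this phenyl ring.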